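The source may report more compounds than this note shows. Statements on the series, on what has been measured and on what is new or still open speak of the compounds shown alone.

Three compounds share one core: compound 1 is `O=C1C=CC(=O)N1c1cc(C(F)(F)F)cc(C(F)(F)F)c1`, compound 2 is `N#Cc1cc(C(F)(F)F)cc(C(F)(F)F)c1` and compound 3 is `FC(F)(F)c1cc(S)cc(C(F)(F)F)c1`. In an ADME assay for pharmacokinetics, read by HPLC, in phosphate buffer, with a stated time of 72 h, at pH 7.4, tested at 250 uM (on this read-out lower numbers stand for a shorter-lived compound and higher numbers for a longer-lived compound), compound 1 gives < 0.017 h, which is a limit of the assay and not a number, so compound 1 stands at the limit of < 0.017 h in this assay, at which 1 of the 2 values shown sits, with no measured figure of its own. Compound 2 in turn gives in this assay > 50 h, again a limit, sitting at the limit of > 50 h in this assay, at which 1 of the 2 values shown sits. For the measured compounds named here, the only measured step between them, an at least 2900-fold higher number from compound 1 to compound 2 (3.46 log units; beyond the scatter), is therefore bounded by limits at both ends and is known only as a minimum. Compound 3 differs from compound 1 in this way: one sulfur atom in place of a group of 7 heavy atoms (4 carbon, 1 nitrogen, 2 oxygen; one five-membered non-aromatic ring with 1 hetero atom), on an aromatic carbon. The measured step bears on this change in that both remove the same group of 7 heavy atoms from the same aromatic carbon, while what enters is not the same. On that ground an upward step from compound 1 is expected in this assay, roughly an at least 580-fold higher number from compound 1 to compound 3 (2.76 log units; beyond the scatter), without a claim that it must reach the size seen toward compound 2. Compound 3 is accordingly estimated at 10 h, within a range of 1 h to 50 h.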

Compound 3, half-life: > 50 h
Compound 3: a limit, no number (the forecaster's own chance of this, stated with the estimate: 30%); middle value at least 5.0-fold (0.69 log units) from the limit.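

The result shows that the rise on this aromatic carbon, meta to two trifluoromethyl groups, is not tied to cyano as the entering group: in this assay, sulfanyl in place of the group of 7 heavy atoms gives an at least 2900-fold higher number from compound 1 to compound 3 (3.46 log units; beyond the scatter), a large step beyond the scatter and, like the earlier one, known only as a minimum. Compound 3 gives a limit of the assay and not a number, and it is the same limit that compound 2 reaches: the limit of > 50 h in this assay, at which 2 of the 3 values shown sit. With two different entering groups now at that limit, the pattern among the shown compounds is that only compound 1, which carries the five-membered ring with its two carbonyl groups, goes against it and stands at the opposite limit: the limit of < 0.017 h in this assay, at which 1 of the 3 values shown sits.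

The step between compound 2 and compound 3 cannot be read, so the compounds shown do not tell how sulfanyl and cyano compare in this assay. From the compounds shown here alone, whether an amine or a carboxylic acid on the same aromatic carbon would also reach the limit of compound 3 remains open.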